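The source may hold more compounds than are shown below. What is called first, only, known or untested is meant among the compounds shown, and "the series" means these compounds.

Measured compounds:
- Compound 1 `c1ccc(CO/N=C2/C(c3c[nH]c4ccccc34)=Nc3ccccc32)cc1`: in a functional assay on NCI-H460 cells (Homo sapiens) for cytotoxicity, read by MTT assay, with a stated time of 2 days (a lower number here means a stronger inhibitor, a higher number a weaker inhibitor), compound 1 gives 22000 nM
- Compound 2 `Fc1ccc2c(c1)/C(=N\OCc1ccccc1)C(c1c[nH]c3ccc(F)cc13)=N2`: in this assay compound 2 gives 12000 nM

Going by the values given here, of the two numbers so far, compound 1 has the higher one, with compound 2 nearest to it; the gap between them lies within the scatter, so the two cannot be ordered. The step now followed leads from compound 1 to compound 3 `FC(F)(F)c1ccc(CO/N=C2/C(c3c[nH]c4ccccc34)=Nc3ccccc32)cc1`. The change is trifluoromethyl in place of hydrogen on an aromatic carbon; read one bond further out, phenyl becomes 4-(trifluoromethyl)phenyl. Among the compounds with values here, no measured pair shows this change, so the expected step rests on compound 1 alone. The author expects no step beyond the scatter, with the estimated step from compound 1 to compound 3 being a 1.2-fold lower number from compound 1 to compound 3 (0.09 log units; within the scatter). For compound 3 the expected value in this assay is 18000 nM, within a range from 6000 nM to 50000 nM.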

Compound 3, half-maximal inhibitory concentration: 24100 nM
Beside the measured number, compound 3's estimate is 1.3-fold (0.13 log units) below it, within the range that was stated.
By their numbers in this assay, from the lowest: compounds 2, 1 and 3 (each within the scatter of the next).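

Going by these compounds alone, the first readable step at this position in this assay is phenyl to 4-(trifluoromethyl)phenyl (a 1.1-fold higher number from compound 1 to compound 3 (0.04 log units; within the scatter)). The aromatic carbon on this ring therefore carries trifluoromethyl, with its 4 heavy atoms, in place of hydrogen without a change that can be told from the scatter. Nothing given here explains this result.

This single substitution leaves open whether a different group at the same place, such as an amine, a methoxy group or a carboxylic acid, would move the number in this assay beyond the scatter. On these data alone, it is also open whether trifluoromethyl would behave in the same way on the fluorinated compound 2, and whether any change at this position can separate a compound from compound 1.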